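This account rests on a few compounds, and the source may have more. Where it says the series, first, only, none or still open, it means among the compounds named here.

In a functional assay on HeLa cells (Homo sapiens) for cytotoxicity, with a stated time of 72 h (on this read-out lower numbers stand for stronger inhibition and higher numbers for weaker inhibition), two compounds have been tested so far. Compound 1 `Clc1ccc(Cc2nn3c(Br)c(-c4ccccc4)nc3s2)cc1` gave only a limit, > 250000 nM, so no number is known for it. Among the measured compounds shown here, compound 2 `N#CSc1c(-c2ccc(Cl)cc2Cl)nc2sc(Cc3ccc(Cl)cc3)nn12` gives 18000 nM, the only number in this assay. The other result, that of compound 1, is a limit, as the limit of > 250000 nM in this assay, at which 1 of the 2 values shown sits, records. Compound 3 `N#CSc1c(-c2ccccc2)nc2sc(Cc3ccc(Cl)cc3)nn12` has not yet been measured in this assay. It differs from compound 2 in one place: phenyl in place of 2,4-dichlorophenyl on an aromatic carbon. For the measured compounds named here, no step between two measured compounds has been computed for this assay, so the size of this change can only be expected, not read off. Compound 3 is expected to be weaker in this assay than compound 2, with an estimated step of a 3.3-fold higher number from compound 2 to compound 3 (0.52 log units; beyond the scatter) that would lie beyond the usual scatter. Compound 3 is therefore estimated at 60000 nM in this assay, with a range from 15000 nM to 250000 nM.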

Compound 3, half-maximal inhibitory concentration: 12000 nM
Beside the measured number, compound 3's estimate is 5.0-fold (0.70 log units) above it; measured number outside the range, below it.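

In this assay, phenyl takes the place of 2,4-dichlorophenyl on this aromatic carbon with no change beyond the scatter (a 1.5-fold lower number from compound 2 to compound 3 (0.18 log units; within the scatter)). Among the compounds shown here, with phenyl held constant, cyanosulfanyl in place of bromo gives the only step here that lies beyond the scatter (an at least 20-fold lower number from compound 1 to compound 3 (1.31 log units; beyond the scatter)), so of these two single changes it is the one that shows up in the read-out. The value for compound 1 is only a limit, so this step has no fixed size: the limit of > 250000 nM in this assay, at which 1 of the 3 values shown sits.

With only phenyl and 2,4-dichlorophenyl shown on this carbon, it remains open how a 4-chlorophenyl group, a pyridine ring or a carboxylic acid there would read. As far as these compounds go, it also remains open whether a nitrile or a methylsulfanyl group could stand in for cyanosulfanyl.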